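This account rests on a few compounds, and the source may have more. Where it says the series, first, only, none or still open, it means among the compounds named here.

Measured in an assay on CHO cells for displacement of a labelled ligand from 5-hydroxytryptamine receptor 1D (Homo sapiens); on this read-out higher numbers stand for weaker inhibition and lower numbers for stronger inhibition: compound 1 `CC(=O)Nc1ccc([C@H](C)NCC2CCN(CCCc3c[nH]c4ccc(-n5cnnc5)cc34)CC2)cc1` gives 0.6 nM; compound 2 `c1ccc(NCC2CCN(CCCc3c[nH]c4ccc(-n5cnnc5)cc34)CC2)nc1` gives 1.7 nM.

Going by the values given here, on these two numbers compound 2 stands highest, with compound 1 as its only and nearest neighbour, the gap being a 2.8-fold higher number from compound 1 to compound 2 (0.45 log units; beyond the scatter). Compound 3 `c1ccc2c(c1)CCC2NCC1CCN(CCCc2c[nH]c3ccc(-n4cnnc4)cc23)CC1` differs from compound 2 by 2,3-dihydro-1H-inden-1-yl in place of pyridin-2-yl on an amine nitrogen. Among the compounds with values here, the one measured step that bears on this exchange is the same one, in which the amine nitrogen substituent also changed from a single aromatic ring to a group carrying an additional ring. For compound 3 a step of modest size toward a lower number, or none beyond the scatter, is therefore expected: a 1.7-fold lower number from compound 2 to compound 3 (0.23 log units; within the scatter). The estimate for compound 3 is 1 nM, within 0.3 nM to 3.5 nM.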

Compound 3, half-maximal inhibitory concentration: 1.1 nM
Beside the measured number, compound 3's estimate is 1.1-fold (0.04 log units) below it, within the range that was stated.
By their numbers in this assay, from the lowest: compounds 1, 3 and 2 (each within the scatter of the next, the first and the last beyond it).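

In this assay, the amine nitrogen takes 2,3-dihydro-1H-inden-1-yl in place of pyridin-2-yl with a 1.5-fold lower number from compound 2 to compound 3 (0.19 log units; within the scatter), so losing the ring hetero atom and its hydrogen-bond acceptor brings no step beyond the scatter here. The same group in place of 1-(4-acetamidophenyl)ethyl gives a 1.8-fold higher number from compound 1 to compound 3 (0.26 log units; within the scatter), placing compound 3 within the scatter of both compounds that stood apart. Nothing at hand explains these steps. Open, going by these compounds, is how a cyclohexyl group or a carboxylic acid on this amine nitrogen would read.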